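The source may hold more compounds than are shown below. What is called first, only, known or untested is meant among the compounds shown, and "the series" means these compounds.

Compound 1 `Cc1cc(COc2ccc(S(=O)(=O)NC3(CC(=O)NO)CN(C(=O)CC(C)C)C3)cc2)c2ccccc2n1`: 900000 nM
Compound 2 `Cc1cc(COc2ccc(S(=O)(=O)NC3(CC(=O)NO)CN(C(=O)C(C)(C)N(C)C)C3)cc2)c2ccccc2n1`: 11000000 nM

Among the measured compounds shown here, in a physicochemical assay for solubility, with a stated time of 24 h, tested at 30 mg/mL (a lower number here means a less soluble compound, a higher number a more soluble compound), compound 1 gives 900000 nM, the lower of the two numbers so far. For the measured compounds named here, the only measured step, a 12-fold higher number from compound 1 to compound 2 (1.09 log units; beyond the scatter), is large and beyond the scatter. That step swaps the group on a carbonyl carbon, with 1-(dimethylamino)-1-methylethyl in place of isobutyl.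

Compound 3 `Cc1cc(COc2ccc(S(=O)(=O)NC3(C(=O)NO)CN(C(=O)CC(C)C)C3)cc2)c2ccccc2n1` differs from compound 1 at another place, and it keeps the isobutylcarbonyl group. The change is hydroxycarbamoyl in place of (hydroxycarbamoyl)methyl on a saturated ring carbon. In words, hydroxycarbamoyl stands in place of (hydroxycarbamoyl)methyl on a saturated ring carbon of a four-membered non-aromatic ring with 1 nitrogen. Neither group has a ring or a net charge.

The measured step therefore bears on this change only indirectly. Going by the values given here, it shows that the number can move a long way within this small series, but no measurement yet tests this place. No step beyond the scatter is expected in this assay, and the expected step is a 1.1-fold higher number from compound 1 to compound 3 (0.05 log units; within the scatter). The range stays wide to allow for that gap. Compound 3 is estimated at 1000000 nM, with an expected range of 300000 nM to 3500000 nM.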

Compound 3, solubility: 5000000 nM
Compound 3: middle estimate off by 5.0-fold (0.70 log units), on the low side, outside the stated range (above it).
By their numbers in this assay, from the lowest: compound 1; then compound 3; then compound 2.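

In this assay, this position on a saturated ring carbon of the four-membered non-aromatic ring proves able to move the number on its own: hydroxycarbamoyl in place of (hydroxycarbamoyl)methyl gives a 5.6-fold higher number from compound 1 to compound 3 (0.74 log units; beyond the scatter). Among the compounds shown here, until now, the only measured change was on the carbonyl carbon of the isobutylcarbonyl group, so this is the first sign that a second place in the molecule matters, and the change here is a small one, with 4 heavy atoms in place of 5, the same counts of hydrogen-bond donors and acceptors, and no net charge on either group. No measurement here explains why so small a change gives a step of this size.

The compounds shown leave open whether the number keeps moving along this position with a longer chain, such as (hydroxycarbamoyl)ethyl, or with a carboxylic acid in place of the hydroxycarbamoyl group. They also leave open whether hydroxycarbamoyl and the 1-(dimethylamino)-1-methylethyl group of compound 2 would add up when placed together on the shared core.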